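From an Aromatic Ring to a Saturated One at the Amide

A few compounds are considered here, and "the series" means these few. Any claim that something is new, unique, unknown or untested is made for them only; others in the source may bear on it.

Compound 3 `O=C(c1cccnc1)N1CCC(NS(=O)(=O)c2cc(S(=O)(=O)c3ccccc3)ccc2C(F)(F)F)CC1` shares its core with compound 1 `O=C(c1ccccc1)N1CCC(NS(=O)(=O)c2cc(S(=O)(=O)c3ccccc3)ccc2C(F)(F)F)CC1` and compound 2 `CN(C)c1ccc(C(=O)N2CCC(NS(=O)(=O)c3cc(S(=O)(=O)c4ccccc4)ccc3C(F)(F)F)CC2)cc1`; the three differ only in the group attached to the carbonyl carbon of the amide. In an assay on isolated protein for displacement of a labelled ligand from secreted frizzled-related protein 1 (Homo sapiens), read by fluorescence polarization, with a stated time of 30 min (on this read-out lower numbers stand for stronger inhibition and higher numbers for weaker inhibition), compound 1 gives 70 nM, compound 2 gives 300 nM, and compound 3 gives 80 nM. Compound 3 thus stands second highest of the three numbers, close to compound 1 and well apart from compound 2.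

Compound 4 `CC(C)(C)OC(=O)N1CC[C@@H](C(=O)N2CCC(NS(=O)(=O)c3cc(S(=O)(=O)c4ccccc4)ccc3C(F)(F)F)CC2)C1` arises from compound 3 by the change (1-(tert-butoxycarbonyl)pyrrolidin-3-yl in place of pyridin-3-yl on a carbonyl carbon). For the measured compounds named here, no measured step replaces an aromatic group with a non-aromatic one at this carbonyl carbon. The nearest comparisons are the step of a 1.1-fold higher number from compound 1 to compound 3 (0.06 log units; within the scatter), which stayed within the scatter, and the steps of a 4.3-fold higher number from compound 1 to compound 2 (0.63 log units; beyond the scatter) and a 3.8-fold lower number from compound 2 to compound 3 (0.57 log units; beyond the scatter), each modest. Together they show that the group on this carbonyl carbon can move the number, but so far only modestly. Going by the values given here, the present change is larger than any of those and has no direct precedent, so the expectation is wide. Compound 4 is expected to give a somewhat higher number, 200 nM, within a range from 50 nM to 800 nM. The expected shift is a 2.5-fold higher number from compound 3 to compound 4 (0.40 log units; beyond the scatter).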

Compound 4, half-maximal inhibitory concentration: 50 nM
Compound 4: middle estimate off by 4.0-fold (0.60 log units), on the high side; low and high end bracket the measured number.
By their numbers in this assay, from the lowest: compounds 4, 1 and 3 (each within the scatter of the next); then compound 2.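

In this assay, an aromatic ring on this carbonyl carbon can give way to a non-aromatic one with no real shift in the number: a 1.6-fold lower number from compound 3 to compound 4 (0.20 log units; within the scatter) and a 1.4-fold lower number from compound 1 to compound 4 (0.15 log units; within the scatter) both stay within the scatter, even though 1-(tert-butoxycarbonyl)pyrrolidin-3-yl brings 12 heavy atoms where pyridin-3-yl has 6. The position is therefore not limited to flat aromatic groups or to groups the size of pyridin-3-yl, and among the four compounds the larger group does not by itself raise the number, while a 6.0-fold lower number from compound 2 to compound 4 (0.78 log units; beyond the scatter), a modest step beyond the scatter, leaves the 4-(dimethylamino)phenyl group of compound 2 as the one that stands apart. Nothing available explains why these groups read alike.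

On these data alone, it remains open whether the tert-butoxycarbonyl group contributes at all, or whether the same pyrrolidine ring carrying a free ring amine would give a similar number. As far as these compounds go, the role of the defined stereocentre is also open, as is how the opposite configuration at that carbon would read in this assay.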